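The compounds below may be only part of what the source reports. "The series", "measured", "known", "first", "only" and "open" are said of these compounds alone.

Compound 1 `O=S(=O)(NCCNCc1ccc(-c2ccccc2)cc1)c1cc(C(F)(F)F)cc(C(F)(F)F)c1`: 1400 nM
Compound 2 `O=S(=O)(NCCCNCc1cccc(Cl)c1)c1cc(C(F)(F)F)cc(C(F)(F)F)c1`: 2600 nM

In a functional assay on MCF7 cells (Homo sapiens) for inhibition, read by MTT assay, with a stated time of 72 h (a higher number here means a weaker inhibitor of growth, a lower number a stronger inhibitor of growth), compound 1 gives 1400 nM and compound 2 gives 2600 nM. Of these two numbers, that of compound 2 is the higher, but its gap to compound 1 lies within the scatter, so the two compounds are not told apart by these data. For the measured compounds named here, no step between measured compounds is given that would show what a single change does.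

Compound 3 `O=S(=O)(NCCCNCc1ccc(Br)cc1)c1cc(C(F)(F)F)cc(C(F)(F)F)c1` has not been measured. It differs from compound 2 in one place: 4-bromophenyl in place of 3-chlorophenyl on a saturated chain carbon bound to an amine nitrogen.

Going by the values given here, with no measured step to draw on, there is no evidence that this change moves this assay beyond the scatter in either direction; the expectation is a step of no clear size. Compound 3 is therefore expected to give 2500 nM, with a range from 1000 nM to 6000 nM, which means an expected step of a 1.0-fold lower number from compound 2 to compound 3 (0.02 log units; within the scatter).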

Compound 3, concentration for 50% growth inhibition: 1900 nM
For compound 3 the middle estimate is 1.3-fold (0.12 log units) above the measured one, and the stated range covers the measured number.
By their numbers in this assay, from the lowest: compounds 1, 3 and 2 (each within the scatter of the next).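

In this assay, for the compounds shown here, the exchange of 3-chlorophenyl for 4-bromophenyl on a saturated chain carbon bound to an amine nitrogen gives a 1.4-fold lower number from compound 2 to compound 3 (0.14 log units; within the scatter) and is the first single change measured at this place, so this one swap does not tell compound 2 and compound 3 apart. The two groups differ at once in the halogen and in the number it carries on the ring, and this single step cannot separate those two differences. Nothing given here bears on the size of this step.

As far as these compounds go, whether 4-chlorophenyl or 3-bromophenyl would part the two differences stays open, as does the outcome with a plain phenyl or a pyridyl ring at this place. Also open, from the compounds shown here alone, is what a longer chain between the sulfonamide nitrogen and the amine would do with 4-bromophenyl kept in place.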